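Nitro to Hydroxy on Methyl Ester and Free Acid

This account rests on a few compounds, and the source may have more. Where it says the series, first, only, none or still open, it means among the compounds named here.

Compound 1 `COC(=O)c1c(-c2ccc([N+](=O)[O-])cc2)oc2cc(OC)ccc2c1=O`: in a functional assay on MCF7 cells (Homo sapiens) for cytotoxicity, read by MTT assay, with a stated time of 6 days (on this read-out lower numbers stand for an effect already at smaller amounts and higher numbers for an effect only at larger amounts of compound), compound 1 stands at the limit > 25 ug/mL, a limit of the assay and not a number.
Compound 2 `COC(=O)c1c(-c2ccc(O)cc2)oc2cc(OC)ccc2c1=O`: in this assay compound 2 likewise stands at the limit > 25 ug/mL.
Compound 3 `COc1ccc2oc(-c3ccc([N+](=O)[O-])cc3)c(C(=O)O)c(=O)c2c1`: in this assay compound 3 gives 15.9 ug/mL.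

The change hydroxy in place of nitro on an aromatic carbon gives the step that the two limits leave unreadable from compound 1 to compound 2. The difference between the core of compound 1 and the core of compound 3 is not broken down here. Compound 4 `COc1ccc2oc(-c3ccc(O)cc3)c(C(=O)O)c(=O)c2c1` is not yet measured; it differs from compound 3 by hydroxy in place of nitro on an aromatic carbon, the same change as from compound 1 to compound 2. Only compound 3 gives a number, as the limit of > 25 ug/mL in this assay, at which 2 of the 3 values shown sit, shows where the other two values sit. With the measured step unreadable, a small step is expected, a 1.1-fold higher number from compound 3 to compound 4 (0.05 log units; within the scatter). Compound 4 is estimated at 18 ug/mL, between 8 ug/mL and 40 ug/mL.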

Compound 4, concentration for half-maximal effect: > 25 ug/mL
Compound 4 ended at the assay's limit; the forecaster's own chance of this, stated with the estimate: 35%; middle value at least 1.3-fold (0.14 log units) from the limit.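

In this assay, hydroxy in place of nitro on the free-acid core gives an at least 1.5-fold higher number from compound 3 to compound 4 (0.19 log units; that floor lies within the scatter). Compound 4 stands at a limit and not a number, so the true step may be larger, but what can be read of it does not go beyond the scatter. On the methyl ester core the same change cannot be read, so no size can be carried from one core to the other, and the transfer is neither confirmed nor refuted: the limit of > 25 ug/mL in this assay, at which 3 of the 4 values shown sit.

Open, as far as these compounds go, is how an amine or a nitrile in the same place, on an aromatic carbon para to a large group, would read on either core. Also open, from the compounds shown here alone, is whether any such group would give the methyl ester core a number rather than a limit.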